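Swapping Amino for Phenyl on the Carbonyl

A few compounds are considered here, and "the series" means these few. Any claim that something is new, unique, unknown or untested is made for them only; others in the source may bear on it.

Compound 2 `N#C/C(=C\N1CCN(C(=O)c2ccco2)C1=S)C(N)=O` gives 11700 nM in a functional assay on SF-268 cells (Homo sapiens) for inhibition, read by sulforhodamine B assay, with a stated time of 48 h; a lower number here means a stronger inhibitor of growth, a higher number a weaker inhibitor of growth. Among the measured compounds shown here, the only other number comes from compound 1 `N#C/C(=C\N1CCN(C(=O)c2ccco2)C1=S)C(=O)Nc1ccc(Cl)cc1`, which gives 17800 nM, and the step of a 1.5-fold lower number from compound 1 to compound 2 (0.18 log units; within the scatter) sits within the scatter, so the two compounds cannot be told apart on these data. Compound 3 `N#C/C(=C\N1CCN(C(=O)c2ccco2)C1=S)C(=O)c1ccccc1` differs from compound 2 by phenyl in place of amino on a carbonyl carbon. For the measured compounds named here, the one measured step changed the group on the amide-type nitrogen, not the carbonyl substituent, and stayed within the scatter, so no clear movement is foreseen. Compound 3 is expected at 12000 nM, in the range 5000 nM to 30000 nM. The expected step is a 1.0-fold higher number from compound 2 to compound 3 (0.01 log units; within the scatter).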

Compound 3, concentration for 50% growth inhibition: 31200 nM
The estimate for compound 3 lay 2.6-fold (0.41 log units) below the measured number; measured number above the stated range.
By their numbers in this assay, from the lowest: compounds 2, 1 and 3 (each within the scatter of the next, the first and the last beyond it).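

Phenyl in place of amino on the carbonyl carbon gives a 2.7-fold higher number from compound 2 to compound 3 (0.43 log units; beyond the scatter) in this assay, the first step here beyond the scatter, so this position can respond, with benzoyl the weaker inhibitor of growth than carbamoyl. Phenyl in place of (4-chlorophenyl)amino gives a 1.8-fold higher number from compound 1 to compound 3 (0.24 log units; within the scatter) and does not separate those two compounds. Nothing shown here explains the difference. Still open, as far as these compounds go, is whether the loss follows from removing the amino group or from adding the ring, which a methyl group on this carbonyl carbon could help separate.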